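Swapping the Amide Ring Partner on a Thiophene Core

The source may hold more compounds than are shown below. What is called first, only, known or untested is meant among the compounds shown, and "the series" means these compounds.

Measured compounds:
Compound 1, `Nc1sc(-c2ccc(Cl)cc2)c(-c2ccc(Cl)cc2)c1C(=O)N1CCC(=O)CC1=O`: 9230 nM
Compound 2, `CC(=O)Nc1sc(-c2ccc(Cl)cc2)c(-c2ccc(Cl)cc2)c1C(=O)N1CCCCC1`: 10300 nM

Both compounds were tested in a functional assay on PC-3 cells (Homo sapiens) for inhibition, read by sulforhodamine B assay, with a stated time of 72 h; a higher number here means a weaker inhibitor, a lower number a stronger inhibitor. In this assay compound 1 gives 9230 nM and compound 2 gives 10300 nM. Compound 1 has the lower of the two numbers, but the gap to compound 2 is within the scatter of repeated measurements, so the two values cannot be told apart; neither compound can be called the stronger inhibitor.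

Compound 3, `Nc1sc(-c2ccc(Cl)cc2)c(-c2ccc(Cl)cc2)c1C(=O)N1CCOCC1`, has not yet been measured. It differs from compound 1 in one place: morpholin-4-yl in place of 2,4-dioxopiperidin-1-yl on a carbonyl carbon. Both compounds keep the same shared core, the two chlorophenyl groups and the free amino group; only the ring attached to the carbonyl changes.

For the measured compounds named here, nothing measured so far tracks this particular exchange, so the expectation rests on how little the two measured values differ. The step from compound 1 to compound 3 is expected to be a 1.1-fold higher number from compound 1 to compound 3 (0.03 log units; within the scatter), that is, no change beyond the scatter. Compound 3 is therefore estimated at 10000 nM, with a plausible range from 3500 nM to 30000 nM.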

Compound 3, half-maximal inhibitory concentration: 11700 nM
The estimate for compound 3 lay 1.2-fold (0.07 log units) below the measured number; the measured number falls inside the stated range.
By their numbers in this assay, from the lowest: compounds 1, 2 and 3 (each within the scatter of the next).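

In this assay, putting morpholin-4-yl in place of 2,4-dioxopiperidin-1-yl on the carbonyl carbon gives a 1.3-fold higher number from compound 1 to compound 3 (0.10 log units; within the scatter) and so produces no change that can be told from the scatter. For the compounds shown here, this is the first direct reading at this position, and it shows that the ring on the carbonyl can be exchanged without a measurable shift, even though the group that leaves has 8 heavy atoms, 2 double bonds outside aromatic rings and 2 hydrogen-bond acceptors, while the group that enters has 6 heavy atoms, no such double bonds and 1 hydrogen-bond acceptor. No measurement at hand offers an explanation for this flat result.

As far as these compounds go, both groups compared here are six-membered non-aromatic rings with no hydrogen-bond donors and no net charge, so it remains open whether a piperazin-1-yl ring with its free ring amine, or a ring carrying a carboxylic acid, would also leave the number where it is. Compound 2 differs from compound 1 and compound 3 in more than one place, so it gives no separate reading of this position.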